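This account rests on a few compounds, and the source may have more. Where it says the series, first, only, none or still open, it means among the compounds named here.

Measured compounds:
compound 1 `CC(C)C[C@H](NC(=O)[C@H](C)NC(=O)c1cccnc1)C(=O)N[C@@H](CCCC[N+](C)(C)C)C(=O)N[C@@H](CO)C(N)=O`, 91000 nM
compound 2 `CC(C)C[C@H](NC(=O)[C@H](C)NC(=O)OCc1ccccc1)C(=O)N[C@@H](CCCC[N+](C)(C)C)C(=O)N[C@@H](CO)C(N)=O`, 58000 nM

Both were read in an assay on isolated protein for displacement of a labelled ligand from Chromobox protein homolog 7 (Homo sapiens), read by fluorescence polarization, with a stated time of 15 min; on this read-out higher numbers stand for weaker inhibition and lower numbers for stronger inhibition. Compound 2 gives the lower of the two numbers, but the step of a 1.6-fold lower number from compound 1 to compound 2 (0.20 log units; within the scatter) lies within the scatter, so the two compounds are not distinguished.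

Compound 3 `CC(C)C[C@H](NC(=O)[C@H](C)NS(=O)(=O)c1cccnc1)C(=O)N[C@@H](CCCC[N+](C)(C)C)C(=O)N[C@@H](CO)C(N)=O` has not yet been measured. It differs from compound 2 by (pyridin-3-yl)sulfonyl in place of benzyloxycarbonyl on an amine nitrogen. Among the measured compounds shown here, the only step available, a 1.6-fold lower number from compound 1 to compound 2 (0.20 log units; within the scatter), swaps the same benzyloxycarbonyl against a pyridine-bearing carbonyl group and shows no change beyond the scatter. Nothing measured in the series bears on a sulfonyl in this place. The expectation for compound 3 is therefore a number close to that of compound 2, with the step of a 1.6-fold higher number from compound 2 to compound 3 (0.19 log units; within the scatter) expected to stay near or within the scatter. Compound 3 is estimated at 90000 nM, with a range of 35000 nM to 250000 nM.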

Compound 3, half-maximal inhibitory concentration: > 250000 nM
Compound 3: only a limit was reported; the forecaster's own chance of this, stated with the estimate: 25%; at least 2.7-fold (0.44 log units) between middle value and limit.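

Earlier, changing the group on this amine nitrogen from (pyridin-3-yl)carbonyl to benzyloxycarbonyl gave no separable difference; with the pyridin-3-yl kept and only carbonyl exchanged for sulfonyl, the result is an at least 2.7-fold higher number from compound 1 to compound 3 (0.43 log units; beyond the scatter), so at this position the linking group counts and not only the ring it carries. The comparison with the benzyloxycarbonyl compound points the same way, with an at least 4.3-fold higher number from compound 2 to compound 3 (0.63 log units; beyond the scatter). The reading for compound 3 is a limit and not a number: the limit of > 250000 nM in this assay, at which 1 of the 3 values shown sits.

From the compounds shown here alone, how far compound 3 lies past that limit stays open, so both steps give only a minimum size. Also open, going by these compounds, is whether a phenylsulfonyl or benzylsulfonyl group on the same amine nitrogen follows (pyridin-3-yl)sulfonyl, or whether a urea carbonyl keeps the level of the carbonyl-linked compounds.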